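Trimming a Side Chain: From Isopropyl to Methyl

This account rests on a few compounds, and the source may have more. Where it says the series, first, only, none or still open, it means among the compounds named here.

Measured so far:
- compound 1, `CC(C)c1ccc(NC2=NCCC3(CCCCC3)S2)cc1`: 1.45
- compound 2, `Fc1ccc(NC2=NCCC3(CCCCC3)S2)cc1Cl`: 0.95
- compound 3, `CNC1=NCCC2(CCCCC2)S1`: 0.91

Of the compounds shown here, three sharing one core have been tested in a physicochemical assay for lipophilicity, at pH 7.4; a higher number here means a more lipophilic compound, a lower number a more polar compound. Compound 1 stands highest of the three numbers, and both of the others lie beyond the scatter below it. Compound 4, `Cc1ccc(NC2=NCCC3(CCCCC3)S2)cc1`, has not been measured yet. It differs from compound 1 in one place: methyl in place of isopropyl on an aromatic carbon. Going by the values given here, no measured pair shows this kind of change directly, so the size of the step is uncertain. Carbon being removed from the structure, the expected step of a number 0.85 log units lower from compound 1 to compound 4 (beyond the scatter) is downward and beyond the scatter. Compound 4 is therefore estimated at 0.6, within a range from 0.25 to 0.95.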

Compound 4, distribution coefficient: 1.48
Beside the measured number, compound 4's estimate is 0.88 log units below it; measured number above the stated range.
By their numbers in this assay, from the lowest: compounds 3 and 2 (each within the scatter of the next); then compounds 1 and 4 (each within the scatter of the next).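

Replacing isopropyl with methyl on this aromatic carbon gives a number 0.03 log units higher from compound 1 to compound 4 (within the scatter) in this assay. Going by these compounds alone, this is the first direct reading of a change at this position, and it shows that losing these carbon atoms here need not shift the number. Within the data shown here, nothing measured so far accounts for this result. The compounds shown leave open whether an amine or a carboxylic acid on the same aromatic carbon would move the number beyond the scatter. As far as these compounds go, a longer chain there is equally open.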